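The source may report more compounds than this note shows. Statements on the series, on what has been measured and on what is new or still open speak of the compounds shown alone.

Going by the values given here, in a functional assay on DU-145 cells (Homo sapiens) for inhibition, read by trypan blue exclusion, with a stated time of 96 h (a higher number here means a weaker inhibitor of growth, a lower number a stronger inhibitor of growth), compound 2 `COc1ccc(/C=C(\C(=O)c2ccc(Br)cc2)S(=O)(=O)Cc2ccc(F)cc2)cc1` gives 25000 nM, the highest of the two numbers so far, while compound 1 `Cc1ccc(/C=C(\C(=O)c2ccc(Br)cc2)S(=O)(=O)Cc2ccc(F)cc2)s1` gives 1000 nM. Compound 3 `COc1ccccc1/C=C(\C(=O)c1ccc(Br)cc1)S(=O)(=O)Cc1ccc(F)cc1` keeps the same atoms as compound 2 but joins them differently: 2-methoxyphenyl in place of 4-methoxyphenyl on a double-bonded chain carbon bound to a double-bonded chain carbon. The methoxy group stays on the ring, and the ring stays on a double-bonded chain carbon bound to a double-bonded chain carbon. Among the compounds with values here, one measured step bears on this, at that same place: a 25-fold higher number from compound 1 to compound 2 (1.40 log units; beyond the scatter). Within the data shown here, it is large, but it exchanges one whole group for another, and no measured compound carries 2-methoxyphenyl, so the direction of the new step remains uncertain. A smaller step is expected, leaning toward a lower number, as compound 2 already gives 25000 nM. The expected change is a 2.5-fold lower number from compound 2 to compound 3 (0.40 log units; beyond the scatter). For compound 3 the estimated value is 10000 nM, with an expected range of 2000 nM to 40000 nM.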

Compound 3, concentration for 50% growth inhibition: 25000 nM
Compound 3: the middle estimate sits 2.5-fold (0.40 log units) below what was measured; measured number inside the range.
By their numbers in this assay, from the lowest: compound 1; then compounds 2 and 3 (each within the scatter of the next).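

In this assay the shift from 4-methoxyphenyl to 2-methoxyphenyl on a double-bonded chain carbon bound to a double-bonded chain carbon gives no change at the digits printed from compound 2 to compound 3 (within the scatter) and leaves the two methoxyphenyl compounds indistinguishable here. The replacement of 5-methylthiophen-2-yl by 2-methoxyphenyl gives a 25-fold higher number from compound 1 to compound 3 (1.40 log units; beyond the scatter) and shows that the large gap to compound 1 is not confined to 4-methoxyphenyl. Nothing available explains either step.

From the compounds shown here alone, whether the lower number of compound 1 belongs to 5-methylthiophen-2-yl in particular stays open, as the comparison covers only the two methoxyphenyl groups. A phenyl ring carrying an amine or a carboxylic acid at this place would test whether other substituents also leave the number unchanged, and whether the same pattern holds with the rest of the core altered is also unresolved.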